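Swapping Methyl for Oxolan-2-yl: An Expected Modest Gain

The source may hold more compounds than are shown below. What is called first, only, known or untested is meant among the compounds shown, and "the series" means these compounds.

Compound 2, with structure `Cc1cc(C)c(CN2CCc3c(Cl)cc([C@H](C)CO)c(Cl)c3C2=O)c(=O)[nH]1`, belongs to a small group of inhibitors built on one shared core. Among the compounds with values here, in an assay on cells for inhibition of histone-lysine N-methyltransferase EZH2 (Homo sapiens), read by ELISA, with a stated time of 72 h (a higher number here means a weaker inhibitor, a lower number a stronger inhibitor), compound 2 gives 129 nM; this is the only number reported for it, and two further entries yielded no single figure. Two companions show how widely repeated readings of this kind can spread. Compound 1, with structure `Cc1cc(C)c(CN2CCc3c(Cl)cc(C(CO)c4ccon4)c(Cl)c3C2=O)c(=O)[nH]1`, gives 7960 nM; 273 nM (2 entries) in this assay, as the entries the several entries of compound 1 in this assay, 7960 nM; 273 nM (2 entries) make plain. Compound 3, with structure `Cc1cc(C)c(CN2CCc3c(Cl)cc(C(CO)C4CCOC4)c(Cl)c3C2=O)c(=O)[nH]1`, gives 1010 nM; 15 nM (2 entries) in this assay, as seen in the several entries of compound 3 in this assay, 1010 nM; 15 nM (2 entries). Compound 4, with structure `Cc1cc(C)c(CN2CCc3c(Cl)cc([C@@H](CO)[C@@H]4CCCO4)c(Cl)c3C2=O)c(=O)[nH]1`, has not yet been measured. It differs from compound 2 by oxolan-2-yl in place of methyl on a saturated chain carbon bound to an aromatic carbon and a saturated chain carbon. Within the data shown here, no measured pair carries exactly this change, so any expectation rests only on the three compounds above and on the spread they reveal. The expected step is a 2.2-fold lower number from compound 2 to compound 4 (0.33 log units; beyond the scatter), a modest gain in inhibitory strength that may well stay within the usual scatter. The estimate for compound 4 in this assay is 60 nM, with a range from 10 nM to 400 nM.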

Compound 4, half-maximal inhibitory concentration in the histone-lysine N-methyltransferase EZH2 assay: 1570 nM
The estimate for compound 4 lay 26-fold (1.42 log units) below the measured number; the measured number lies above the stated range.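

In the histone-lysine N-methyltransferase EZH2 assay, oxolan-2-yl in place of methyl on a saturated chain carbon bound to an aromatic carbon and a saturated chain carbon gives a 12-fold higher number from compound 2 to compound 4 (1.09 log units; beyond the scatter), so in this pair the added ring comes with a clear loss of inhibitory strength. The earlier compounds shown here also carry a ring at this carbon, but their repeated entries spread too widely to show what a ring does there, as compound 3 illustrates: the several entries of compound 3 in the histone-lysine N-methyltransferase EZH2 assay, 1010 nM; 15 nM (2 entries). Within the data shown here, compound 4 gives the first single reading for such a ring, and it comes with lower lipophilicity in a physicochemical assay for lipophilicity, at pH 7.4 (on this read-out lower numbers stand for lower lipophilicity and higher numbers for higher lipophilicity), although one pair cannot show whether the two shifts are linked: the measured distribution coefficient of compound 2, 2.6, and of compound 4, 2.1, a number 0.50 log units lower (beyond the scatter). In the physicochemical assay compound 2 gives 2.6 and compound 4 gives 2.1.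

The compounds shown leave open whether the loss follows from the ring itself, its oxygen or the defined stereocentre. Cyclopentyl, which keeps a five-membered ring without the oxygen, and ethyl, a short open chain with no ring, would help to separate these possibilities, as would the opposite stereoisomer of compound 4.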